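The source may hold more compounds than are shown below. What is called first, only, known or untested is meant among the compounds shown, and "the series" means these compounds.

Measured compounds in a functional assay on OVCAR-3 cells (Homo sapiens) for inhibition, read by sulforhodamine B assay, with a stated time of 48 h; a lower number here means a stronger inhibitor of growth, a higher number a weaker inhibitor of growth:
- compound 1 `COc1cc(-c2nn(-c3cccc(NC(=O)Nc4cc(C(F)(F)F)cc(C(F)(F)F)c4)c3)cc2-c2ccncc2)ccc1Cl` — 411 nM
- compound 2 `COc1cc(-c2nn(-c3cccc(NC(=O)c4cccc(C(F)(F)F)c4)c3)cc2-c2ccncc2)ccc1Cl` — 1200 nM
- compound 3 `COc1cc(-c2nn(-c3cccc(NC(=O)Nc4ccc(Cl)c(Cl)c4)c3)cc2-c2ccncc2)ccc1Cl` — 697 nM

Compound 3 stands second highest of the three numbers in this assay; compound 1 is its nearest neighbour and compound 2 its furthest, and both gaps lie within the scatter, so no order among the three can be read from these values.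

Compound 4 `COc1cc(-c2nn(-c3cccc(NC(=O)Nc4cccc(C(F)(F)F)c4)c3)cc2-c2ccncc2)ccc1Cl` is not yet measured. Against compound 3 the change is 3-(trifluoromethyl)phenyl in place of 3,4-dichlorophenyl on an amide-type nitrogen. Going by the values given here, only one measured step touches this end of the molecule: a 1.7-fold lower number from compound 2 to compound 3 (0.24 log units; within the scatter), and it swaps amide for urea at the same time, so it does not isolate the aryl exchange. Compound 1, a urea carrying two trifluoromethyl groups on that ring, gives 411 nM in this assay, within the scatter of compound 3. Among the compounds with values here, nothing among the measured steps points to a change beyond the scatter in this assay, so the estimated step of a 1.4-fold lower number from compound 3 to compound 4 (0.14 log units; within the scatter) is expected to be small. Compound 4 is expected near 500 nM, in the range 250 nM to 1000 nM.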

Compound 4, concentration for 50% growth inhibition: 579 nM
Estimate against measurement, compound 4: 1.2-fold (0.06 log units) below; measured number inside the range.
By their numbers in this assay, from the lowest: compounds 1, 4, 3 and 2 (each within the scatter of the next, the first and the last beyond it).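

In this assay, the exchange of 3,4-dichlorophenyl for 3-(trifluoromethyl)phenyl on the amide-type nitrogen, now seen with the urea held constant, gives a 1.2-fold lower number from compound 3 to compound 4 (0.08 log units; within the scatter). Hydrogen in place of trifluoromethyl on the aromatic ring gives a 1.4-fold higher number from compound 1 to compound 4 (0.15 log units; within the scatter), so neither ring change shown here leaves the scatter. With the 3-(trifluoromethyl)phenyl ring held constant, the amide-to-urea exchange gives a 2.1-fold lower number from compound 2 to compound 4 (0.32 log units; beyond the scatter), a modest step that separates this linker change from the ring exchange combined with it in the earlier step.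

No available evidence explains these readings. Still open, on these data alone, is whether a carboxylic acid or an amine on this ring, or a sulfonamide in place of the urea, would give a step beyond the scatter.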